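The source may report more compounds than this note shows. Statements on the series, on what has been measured and on what is new or still open speak of the compounds shown alone.

Measured so far in an assay on CHO cells for displacement of a labelled ligand from adenosine receptor A1 (Homo sapiens), read by scintillation counting, with a stated time of 3 h; a higher number here means a weaker inhibitor, a lower number a stronger inhibitor: compound 1 `Nc1nc(-c2ccccc2)nc2sc(-c3ccccc3)nc12` gives 148 nM; compound 2 `Nc1nc(-c2cccc(CO)c2)nc2sc(-c3ccccc3)nc12` gives 32 nM; compound 3 `Nc1nc(-c2cccc(O)c2)nc2sc(-c3ccccc3)nc12` gives 58.5 nM.

Compound 3 holds the second highest of the three numbers: a 2.5-fold lower number from compound 1 to compound 3 (0.40 log units; beyond the scatter), whereas a 1.8-fold higher number from compound 2 to compound 3 (0.26 log units; within the scatter), a gap within the scatter. Compound 4 `Cc1ccc(-c2nc(N)c3nc(-c4ccccc4)sc3n2)o1` carries 5-methylfuran-2-yl in place of 3-hydroxyphenyl on an aromatic carbon. Within the data shown here, no measured step covers an exchange of the whole aryl group; the steps of a 4.6-fold lower number from compound 1 to compound 2 (0.67 log units; beyond the scatter) and a 2.5-fold lower number from compound 1 to compound 3 (0.40 log units; beyond the scatter) only show that a hydroxymethyl or hydroxy on the phenyl lowered the number modestly. The expectation for compound 4 is therefore loosely held, with a 1.0-fold higher number from compound 3 to compound 4 (0.01 log units; within the scatter) as the estimated step, nothing beyond the scatter. Compound 4 is expected to give about 60 nM, within a range from 12 nM to 300 nM.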

Compound 4, inhibition constant: 28.9 nM
The estimate for compound 4 lay 2.1-fold (0.32 log units) above the measured number; the range from low to high includes it.
By their numbers in this assay, from the lowest: compounds 4, 2 and 3 (each within the scatter of the next, the first and the last beyond it); then compound 1.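

The phenyl ring is not needed at this position: in this assay, a five-membered 5-methylfuran-2-yl ring with 0 hydrogen-bond donors gives a lower number than either the plain phenyl (a 5.1-fold lower number from compound 1 to compound 4 (0.71 log units; beyond the scatter)) or the 3-hydroxyphenyl (a 2.0-fold lower number from compound 3 to compound 4 (0.31 log units; beyond the scatter)). Against the 3-(hydroxymethyl)phenyl the exchange stays within the scatter (a 1.1-fold lower number from compound 2 to compound 4 (0.04 log units; within the scatter)), so the hydroxy-bearing groups of the earlier compounds are not required to reach this level. Nothing available explains these steps.

The compounds shown leave open what the methyl on the furan contributes, since no furan without it appears. Going by these compounds, how a thiophene or an amine at this position would compare also remains open.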